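The compounds below may be only part of what the source reports. "The series", "measured", "known", "first", "only" and "open" are said of these compounds alone.

Compound 1 `Nc1ncnc2c1c(-c1cnc3[nH]ccc3c1)nn2CCCCCC(=O)NO` and compound 2 `Nc1ncnc2c1c(-c1cnc3[nH]ccc3c1)nn2CCC(=O)NO` share one core, while compound 3 `Nc1nc2cc(-c3nn(CCCCCC(=O)NO)c4ncnc(N)c34)ccc2o1` carries another; the difference between the two cores is not broken down here. In a functional assay on CNE-2 cells (Homo sapiens) for inhibition, read by MTT assay, with a stated time of 72 h (on this read-out higher numbers stand for weaker inhibition and lower numbers for stronger inhibition), compound 1 reaches only a limit, > 50000 nM. Compound 2 also reaches only a limit, > 150000 nM. Compound 3 gives 37600 nM. Compound 1 differs from compound 2 by 3-(hydroxycarbamoyl)propyl in place of hydroxycarbamoyl on a saturated chain carbon, two bonds along the chain from an aromatic nitrogen, and the step that the two limits leave unreadable from compound 2 to compound 1 is left unreadable by the limit of > 150000 nM in this assay, at which 1 of the 3 values shown sits, and (the limit of > 50000 nM in this assay, at which 1 of the 3 values shown sits). Compound 4 `Nc1nc2cc(-c3nn(CCCCCCCCC(=O)NO)c4ncnc(N)c34)ccc2o1`, not yet measured, differs from compound 3 by 3-(hydroxycarbamoyl)propyl in place of hydroxycarbamoyl on a saturated chain carbon, five bonds along the chain from an aromatic nitrogen, the same kind of change, here sitting five bonds along the chain from an aromatic nitrogen rather than two. With the measured pair giving no size, the expectation rests on compound 3 alone. Compound 4 is expected to give 30000 nM, between 8000 nM and 120000 nM. The expected step is a 1.3-fold lower number from compound 3 to compound 4 (0.10 log units; within the scatter).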

Compound 4, half-maximal inhibitory concentration: 3240 nM
For compound 4 the middle estimate is 9.3-fold (0.97 log units) above the measured one; the whole stated range lies above it.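

On the core of compound 3, putting 3-(hydroxycarbamoyl)propyl in place of hydroxycarbamoyl gives, in this assay, a 12-fold lower number from compound 3 to compound 4 (1.06 log units; beyond the scatter), a large step towards stronger inhibition. The same change on the core of compound 1 cannot be read, so this single result does not show that the step carries over from one core to another, and compound 2 gives only a limit: the limit of > 150000 nM in this assay, at which 1 of the 4 values shown sits. Compound 1 also gives only a limit: the limit of > 50000 nM in this assay, at which 1 of the 4 values shown sits.

Going by these compounds alone, whether a longer chain than the one in compound 4 would lower the number further remains open. So does the effect of a carboxylic acid in place of the hydroxycarbamoyl group at the chain end.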